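Replacing the tert-butyl group of compound 2

A few compounds are considered here, and "the series" means these few. Any claim that something is new, unique, unknown or untested is made for them only; others in the source may bear on it.

Going by the values given here, in a functional assay on HCT-116 cells (Homo sapiens) for antiproliferative activity, read by MTT assay, with a stated time of 72 h (a lower number here means a stronger inhibitor, a higher number a weaker inhibitor), compound 2 (`CC(C)(C)c1ccc(NC(=O)CCc2cccc3c2B(O)OC3)cc1`) gives 19000 nM, the lower of the two numbers measured so far, and compound 1 (`C#Cc1ccc(NC(=O)CCc2cccc3c2B(O)OC3)cc1`) gives 45000 nM. Compound 3 (`CC(C)(C)OC(=O)Nc1ccc(NC(=O)CCc2cccc3c2B(O)OC3)cc1`) has (tert-butoxycarbonyl)amino in place of tert-butyl on an aromatic carbon, para to a large group: (tert-butoxycarbonyl)amino in place of tert-butyl on an aromatic carbon. Among the compounds with values here, only one measured step bears on this change, since it concerns the same place on the ring. That step is a 2.4-fold lower number from compound 1 to compound 2 (0.37 log units; beyond the scatter), which is modest and lies just beyond the scatter. With this single modest step as the guide, only a small change is expected, and its direction cannot be told from the data. The expected result is a 1.2-fold higher number from compound 2 to compound 3 (0.06 log units; within the scatter). For compound 3 the estimated value is 22000 nM, with an expected range from 8000 nM to 55000 nM.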

Compound 3, half-maximal inhibitory concentration: 24000 nM
For compound 3 the middle estimate is 1.1-fold (0.04 log units) below the measured one; the measured number falls inside the stated range.
By their numbers in this assay, from the lowest: compounds 2, 3 and 1 (each within the scatter of the next, the first and the last beyond it).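

In this assay, the position on the aromatic carbon accepts (tert-butoxycarbonyl)amino, which has more heavy atoms than tert-butyl and brings a hydrogen-bond donor and acceptors, with only a 1.3-fold higher number from compound 2 to compound 3 (0.10 log units; within the scatter). Against ethynyl, the same group gives a 1.9-fold lower number from compound 1 to compound 3 (0.27 log units; within the scatter), so compound 3 cannot be told apart from either of the other two compounds, even though those two differ from each other beyond the scatter. Across these three compounds, adding the carbamate-bearing group at this position therefore leaves the number within the span already set by ethynyl and tert-butyl. No measurement is available here that would explain this result. Going by these compounds, it remains open whether a free amine or a carboxylic acid at this position would move the number beyond that span, and whether a longer chain would do so.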